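This account rests on a few compounds, and the source may have more. Where it says the series, first, only, none or still open, it means among the compounds named here.

Among the compounds with values here, compound 2 `CC[C@@H](Nc1c(C#N)c(-c2ccc(-c3ccc(OC)cc3)cc2)nc2cnccc12)C(N)=O` is one of two compounds so far measured in a physicochemical assay for lipophilicity, read by HPLC, at pH 7.5; a lower number here means a more polar compound, a higher number a more lipophilic compound. In this assay compound 2 gives 2.7, the higher of the two numbers. Compound 1 `CCOc1ccccc1-c1ccc(-c2nc3cnccc3c(N[C@H](CC)C(=O)NS(=O)(=O)C3CC3)c2C#N)cc1` gives 2.3 in this assay, a value lower than that of compound 2 by more than the usual scatter of the measurement. Within the data shown here, no pair among the measured compounds differs in only one place, so no single structural change has yet been tied to a shift in this assay.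

Compound 3 `CC[C@@H](Nc1c(C#N)c(-c2ccc(-c3ccccc3CO)cc2)nc2cnccc12)C(N)=O` has not been measured in this assay. It differs from compound 2 in one place: 2-(hydroxymethyl)phenyl in place of 4-methoxyphenyl on an aromatic carbon. The atoms are the same and only their joining changes; the group that enters carries one hydrogen-bond donor where the group that leaves carried none. Among the measured compounds shown here, for compound 3 a modest downward step is expected in this assay, of the size a number 0.50 log units lower from compound 2 to compound 3 (beyond the scatter), though with no measured step of this kind to lean on, the size is uncertain. Compound 3 is therefore estimated at 2.2 in this assay, with a range from 1.7 to 2.7.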

Compound 3, distribution coefficient: 2.1
The estimate for compound 3 lay 0.10 log units above the measured number; low and high end bracket the measured number.
By their numbers in this assay, from the lowest: compounds 3 and 1 (each within the scatter of the next); then compound 2.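

In this assay, exchanging 4-methoxyphenyl for 2-(hydroxymethyl)phenyl gives a number 0.60 log units lower from compound 2 to compound 3 (beyond the scatter) and provides the first step tied to a single place in this series. The two groups have the same heavy atoms in number and kind, and both keep the six-membered aromatic ring of carbon only, so this position, on an aromatic carbon para to a large group, registers a shift even when only the joining of those atoms changes. The entering group also carries a hydrogen-bond donor that the leaving group lacks, but no measurement here ties the shift to that donor or to any other feature, so the step stands without a measured explanation.

This one step alters both the kind of oxygen group and where it sits on the ring, leaving open which of the two changes accounts for the shift. On these data alone, the readings of 4-(hydroxymethyl)phenyl, which would keep the place of the methoxy group, and of 2-methoxyphenyl, which would keep the place of the hydroxymethyl group, remain open, as does that of a 2-(aminomethyl)phenyl group carrying an amine at this position.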